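Swapping 4-chlorophenyl for 3-methoxyphenyl on the amide

This account rests on a few compounds, and the source may have more. Where it says the series, first, only, none or still open, it means among the compounds named here.

Measured so far in a physicochemical assay, with a stated time of 30 min (a higher number here means a weaker inhibitor, a lower number a stronger inhibitor), for two compounds:
compound 1 `CCOc1ccc(NC(=O)C2Cc3cc(OC)c(OC)cc3C2=O)cc1` gives 48.2 ug/mL
compound 2 `COc1cc2c(cc1OC)C(=O)C(C(=O)Nc1ccc(Cl)cc1)C2` gives 56.8 ug/mL

Compound 2 at 56.8 ug/mL sits within the usual scatter of compound 1 at 48.2 ug/mL so the two values cannot be told apart. The next compound to be measured is compound 3 `COc1cccc(NC(=O)C2Cc3cc(OC)c(OC)cc3C2=O)c1` with the same core as compound 2 and 3-methoxyphenyl in place of 4-chlorophenyl on an amide-type nitrogen. Going by the values given here, only one measured step bears on this change, chloro in place of ethoxy on an aromatic carbon, and it was a 1.2-fold higher number from compound 1 to compound 2 (0.07 log units; within the scatter) in size. Among the compounds with values here, no measured pair tests the 3-methoxyphenyl group itself, so this guide is thin. Within the data shown here, with that one small step as the only evidence, no change beyond the scatter is expected in this assay and no direction can be favoured. The expected step is a 1.1-fold lower number from compound 2 to compound 3 (0.06 log units; within the scatter) and it remains an estimate. Estimated for compound 3 is 50 ug/mL as the middle value, with 22 ug/mL to 115 ug/mL as its expected range.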

Compound 3, half-maximal inhibitory concentration: 38.9 ug/mL
For compound 3 the middle estimate is 1.3-fold (0.11 log units) above the measured one; the measured number falls inside the stated range.
By their numbers in this assay, from the lowest: compounds 3, 1 and 2 (each within the scatter of the next).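

In this assay, the exchange of 4-chlorophenyl for 3-methoxyphenyl on the amide-type nitrogen gives a 1.5-fold lower number from compound 2 to compound 3 (0.16 log units; within the scatter), so the two compounds cannot be told apart. The earlier step had exchanged only chloro for ethoxy on an aromatic carbon, whereas this one alters both the substituent and its place on the ring, as the names 4-chlorophenyl and 3-methoxyphenyl show, and the read-out still stays within the scatter. So far, then, this position has accepted three differently substituted aromatic rings without a separable difference in this assay, although no measurement shown here offers an explanation for that.

Going by these compounds, all three compounds carry a six-membered aromatic ring of carbon only on the amide-type nitrogen, so it remains open whether a clear difference would appear with a different kind of group there, such as a pyridine ring, a carboxylic acid on the phenyl ring or a saturated cyclohexyl ring. The shared core is also the same throughout, which leaves open how much of the read-out depends on it, for example on its two methoxy groups.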